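Nitro to Chloro: Expecting the Minimum Effective Dose

The source may hold more compounds than are shown below. What is called first, only, known or untested is meant among the compounds shown, and "the series" means these compounds.

Compound 1 `COc1ccc(-n2c(Nc3nc(-c4ccc([N+](=O)[O-])cc4)cs3)n[nH]c2=S)cc1` is tested in a functional assay on the whole organism (strain Swiss albino) for inhibition, with Mus musculus as the target, with a stated time of 4 h (a higher number here means that more compound is needed for the effect, a lower number that less compound is needed), where compound 1 gives 300 mg/kg, the highest of the two numbers at hand. Within the data shown here, its only measured neighbour, compound 2 `COc1ccccc1-n1c(Nc2nc(-c3ccc([N+](=O)[O-])cc3)cs2)n[nH]c1=S`, gives 100 mg/kg. The step of a 3.0-fold lower number from compound 1 to compound 2 (0.48 log units; beyond the scatter) goes with a change on the aromatic nitrogen. Compound 3 `COc1ccc(-n2c(Nc3nc(-c4ccc(Cl)cc4)cs3)n[nH]c2=S)cc1` differs from compound 1 at another place: chloro in place of nitro on an aromatic carbon. Among the measured compounds shown here, no measured step touches that place, so nothing here guides the change, and a step no larger than the scatter is expected, no change at the digits printed from compound 1 to compound 3 (within the scatter). Compound 3 is therefore estimated at 300 mg/kg, within 100 mg/kg to 1000 mg/kg.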

Compound 3, minimum effective dose: 100 mg/kg
The estimate for compound 3 lay 3.0-fold (0.48 log units) above the measured number, and the stated range covers the measured number.
By their numbers in this assay, from the lowest: compounds 2 and 3 (each within the scatter of the next); then compound 1.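

In this assay, the swap to 4-chlorophenyl gives a 3.0-fold lower number from compound 1 to compound 3 (0.48 log units; beyond the scatter) and so shows that this place on the far aromatic ring also affects the dose. The nitro group is not needed for the effect, since compound 3 keeps it with chloro in its place. Nothing available bears on the cause of this step.

From the compounds shown here alone, whether an amine or a carboxylic acid at this place would lower the dose further remains open. So does whether chloro and the 2-methoxyphenyl group would add up in one compound.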